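Thiophene for phenyl on a fused bicyclic core

The source may hold more compounds than are shown below. What is called first, only, known or untested is meant among the compounds shown, and "the series" means these compounds.

Measured compounds:
Compound 1 `C=C(Br)C(=O)Nc1cccc(-c2cn3nc(-c4ccccc4)sc3n2)c1`: 600 nM
Compound 2 `C=C(Br)C(=O)Nc1cccc(-c2cn3c(-c4ccccc4)csc3n2)c1`: 1300 nM

The two compounds were tested in a functional assay on L1210 cells (Mus musculus) for inhibition, read by cell counting, with a stated time of 2 days; on this read-out higher numbers stand for weaker inhibition and lower numbers for stronger inhibition. Compound 1 gives 600 nM, the lowest of the two numbers. Its nearest neighbour, compound 2, gives 1300 nM, a higher number that lies beyond the scatter of repeated measurements. Among the compounds with values here, no step between two measured compounds that differ in one place is available, so the pair says only what these two values show.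

The unmeasured compound 3 `C=C(Br)C(=O)Nc1cccc(-c2cn3nc(-c4cccs4)sc3n2)c1` differs from compound 1 as follows: thiophen-2-yl in place of phenyl on an aromatic carbon. Within the data shown here, no measured pair here shows the effect of such a swap, so there is nothing to anchor the size of the step. The change is expected to stay within the scatter, expressed as no change at the digits printed from compound 1 to compound 3 (within the scatter). Compound 3 is therefore estimated to give 600 nM in this assay, within a range from 250 nM to 1500 nM.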

Compound 3, half-maximal inhibitory concentration: 170 nM
Compound 3: middle estimate off by 3.5-fold (0.55 log units), on the high side; measured number outside the range, below it.
By their numbers in this assay, from the lowest: compound 3; then compound 1; then compound 2.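

In this assay, thiophen-2-yl in place of phenyl gives a 3.5-fold lower number from compound 1 to compound 3 (0.55 log units; beyond the scatter). Within the data shown here, this is the first step in the set that changes one place only, and it shows that the number responds to which aromatic ring sits on this carbon of the five-membered aromatic ring with 2 nitrogen and 1 sulfur. Nothing available bears on why the number moves with this swap.

The compounds shown leave open whether thiophen-3-yl, furan-2-yl, a pyridine ring or a non-aromatic group such as an amine or a short alkyl chain on the same carbon would follow compound 3 or compound 1. They also leave open whether thiophen-2-yl on the core of compound 2 would bring a similar step.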